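The source may report more compounds than this note shows. Statements on the series, on what has been measured and on what is new or still open speak of the compounds shown alone.

Compound 1 `Cc1ccccc1CN1CC=C(CCC(=O)NO)C1=O` and compound 2 `O=C(CCC1=CCN(CCCc2ccc(Br)cc2)C1=O)NO` share one core and carry different groups on the ring nitrogen. In a functional assay on ACHN cells (Homo sapiens) for inhibition, read by sulforhodamine B assay (on this read-out higher numbers stand for weaker inhibition of growth and lower numbers for stronger inhibition of growth), compound 1 gives 3330 nM and compound 2 gives 3330 nM, so compound 2 stands level with compound 1, within the scatter. Compound 3 `O=C(CCC1=CCN(CCCc2ccc(Cl)cc2)C1=O)NO` differs from compound 2 by chloro in place of bromo on an aromatic carbon. Among the measured compounds shown here, no measured pair shows what this exchange does, and the two measured compounds do not separate from each other. A small step is therefore expected, a 1.0-fold lower number from compound 2 to compound 3 (0.00 log units; within the scatter), with no direction beyond the scatter. In this assay compound 3 is expected to give about 3300 nM, with a range from 1500 nM to 7500 nM.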

Compound 3, concentration for 50% growth inhibition: 3330 nM
Estimate against measurement, compound 3: 1.0-fold (0.00 log units) below; the measured number falls inside the stated range.
By their numbers in this assay, from the lowest: compounds 1, 2 and 3 (each within the scatter of the next).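

In this assay, the exchange on the aromatic carbon para to a large group gives no change at the digits printed from compound 2 to compound 3 (within the scatter). This pair isolates a single place, which compounds 1 and 2 could not do, as they carry different groups on the ring nitrogen. Here, 4-bromophenyl and 4-chlorophenyl are not told apart, and nothing available explains this result. As far as these compounds go, whether an amine or a carboxylic acid in place of the halogen would separate from these compounds stays open. So does the outcome of a longer chain on the ring nitrogen.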